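Piperazine aryl group change in alpha-1 binding

This account rests on a few compounds, and the source may have more. Where it says the series, first, only, none or still open, it means among the compounds named here.

Measured compounds:
Compound 1, `CCOc1ccccc1N1CCN(CCCCn2ncc(=O)n(C)c2=O)CC1`: 1.8 nM
Compound 2, `CSc1ccccc1N1CCN(CCCCn2ncc(=O)n(C)c2=O)CC1`: 1.8 nM

In an assay for displacement of a labelled ligand from Adrenergic receptor alpha-1 (Homo sapiens) (a lower number here means a stronger inhibitor, a higher number a weaker inhibitor), compound 2 gives 1.8 nM. Compound 2 stands level with compound 1 at the digits shown, as the step of no change at the digits printed from compound 1 to compound 2 (within the scatter) records: that is the only measured step, and it concerns a substituent on the aromatic ring, not the ring itself.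

Compound 3, `Cn1c(=O)cnn(CCCCN2CCN(c3ccccn3)CC2)c1=O`, has not yet been tested in this assay. It differs from compound 2 in this way: pyridin-2-yl in place of 2-(methylsulfanyl)phenyl on an amine nitrogen in a ring.

Among the compounds with values here, no measured step bears on an exchange of the whole aromatic group on the ring nitrogen. Within the data shown here, the single step available, no change at the digits printed from compound 1 to compound 2 (within the scatter), tells nothing about removing the substituted phenyl ring. Compound 3 is therefore expected to bind more weakly than compound 2, with the step estimated as an 11-fold higher number from compound 2 to compound 3 (1.05 log units; beyond the scatter). For compound 3 the estimated value is 20 nM, expected to lie between 4 nM and 100 nM.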

Compound 3, inhibition constant: 262 nM
Beside the measured number, compound 3's estimate is 13-fold (1.12 log units) below it; the measured number lies above the stated range.
By their numbers in this assay, from the lowest: compounds 1 and 2 (each within the scatter of the next); then compound 3.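

In this assay the amine nitrogen in the ring proves sensitive to the aromatic group it carries, although the earlier exchange of ethoxy for methylsulfanyl on that group left binding level. Pyridin-2-yl in place of 2-(methylsulfanyl)phenyl gives a 150-fold higher number from compound 2 to compound 3 (2.16 log units; beyond the scatter) and pyridin-2-yl in place of 2-ethoxyphenyl gives the same size of loss, a 150-fold higher number from compound 1 to compound 3 (2.16 log units; beyond the scatter) in the printed values. Nothing measured here explains this loss of binding.

The compounds shown leave open how much of the step belongs to the ring nitrogen that enters and how much to the substituent that leaves, since compound 3 changes both at once. An unsubstituted phenyl group on the same nitrogen, or a pyridin-2-yl group carrying an ethoxy group, would separate the two.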